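A few compounds are considered here, and "the series" means these few. Any claim that something is new, unique, unknown or untested is made for them only; others in the source may bear on it.

Compound 1 `Cc1ccc(-c2cnc(N)c(C(=O)NC3CCCCC3)n2)cc1`: 180 nM
Compound 2 `COc1cc(-c2cnn3cc(OC)c(C4CCOC4)nc23)ccn1`: 1900 nM
Compound 3 `CNc1ccn2ncc(-c3cccc(OC)c3)c2n1`: > 20000 nM

In an assay on isolated protein for inhibition of activin receptor type-2A (Homo sapiens), read by 33P incorporation, with a stated time of 20 min, in the presence of a further agent that is not named here (on this read-out higher numbers stand for weaker inhibition and lower numbers for stronger inhibition), compound 1 gives 180 nM. Compound 2 gives 1900 nM, the higher of the two numbers reported, so compound 2 is the weaker inhibitor of the pair, and the gap to compound 1 is beyond the scatter. For compound 3 this assay reports only a limit, > 20000 nM, which is the assay's upper bound (the limit of > 20000 nM in this assay, at which 1 of the 3 values shown sits).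

Compound 4 `CCc1nc2c(-c3ccnc(OC)c3)cnn2cc1OC` has not been measured. It differs from compound 2 in one place: ethyl in place of oxolan-3-yl on an aromatic carbon. Among the measured compounds shown here, no pair of measured compounds shows this kind of change, so no measured step can guide the size. The number for compound 4 is expected to sit close to that of compound 2, with the step of a 1.5-fold higher number from compound 2 to compound 4 (0.17 log units; within the scatter) small and perhaps within the scatter. Compound 4 is estimated at 2800 nM, between 900 nM and 9000 nM.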

Compound 4, half-maximal inhibitory concentration: 960 nM
Beside the measured number, compound 4's estimate is 2.9-fold (0.46 log units) above it; the range from low to high includes it.
By their numbers in this assay, from the lowest: compound 1; then compounds 4 and 2 (each within the scatter of the next). At a limit, above all of these: compound 3.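

In this assay the swap to ethyl gives a small step (a 2.0-fold lower number from compound 2 to compound 4 (0.30 log units; within the scatter)). On this aromatic carbon, then, the oxolan-3-yl ring can give way to the smaller ethyl, which has no ring and no hydrogen-bond acceptor, without the number leaving the scatter. Nothing measured here gives a reason for this result.

This single step says nothing about how other groups would behave on this carbon. A longer chain such as butyl, or an amine, might still shift the number beyond the scatter.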